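Hydrazone aryl exchange on a shared tetrazole thioacetyl core

A few compounds are considered here, and "the series" means these few. Any claim that something is new, unique, unknown or untested is made for them only; others in the source may bear on it.

Cytotoxicity across the series is read in an ADME assay on MT4 cells (Homo sapiens) for cytotoxicity, read by MTT assay; a lower number here means that less compound is tolerated, a higher number that more compound is tolerated. Compound 1, `O=C(CSc1nnnn1-c1cccc2ccccc12)N/N=C/c1cccs1`, reaches only the limit of the assay and is recorded as > 316000 nM. Compound 2, `O=C(CSc1nnnn1-c1cccc2ccccc12)N/N=C/c1cccc(Cl)c1`, gives a number, 240000 nM. Compound 3, `O=C(CSc1nnnn1-c1cccc2ccccc12)N/N=C/c1ccc([N+](=O)[O-])cc1`, again reports a limit rather than a number, >= 260000 nM. Compound 3 therefore stands at a limit, and a second limit, that of compound 1, sits among the three values shown.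

The next analogue is compound 4, `COc1ccc(/C=N/NC(=O)CSc2nnnn2-c2cccc3ccccc23)cc1OC`. Its change from compound 3: 3,4-dimethoxyphenyl in place of 4-nitrophenyl on a carbon with a double bond to nitrogen.

Within the data shown here, the steps that bear on this site are an at least 1.3-fold lower number from compound 1 to compound 2 (0.11 log units; that floor lies within the scatter), a step that the two limits leave unreadable from compound 1 to compound 3 and an at least 1.0-fold higher number from compound 2 to compound 3 (0.03 log units; that floor lies within the scatter). None of these exchanges of the aryl group on the carbon with a double bond to nitrogen has moved this assay beyond the scatter, and two of the three values run into limits (the limit of > 316000 nM in this assay, at which 1 of the 3 values shown sits, (the limit of >= 260000 nM in this assay, at which 1 of the 3 values shown sits)), so their sizes are partly unreadable. For compound 4 the expected step is a step that the limit leaves unreadable from compound 3 to compound 4, nothing beyond the scatter. Compound 4 is estimated at 300000 nM, within 150000 nM to 600000 nM, with a real chance that this assay once more reports only a limit.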

Compound 4, half-maximal cytotoxic concentration: 191000 nM
For compound 4 the middle estimate is 1.6-fold (0.20 log units) above the measured one, within the range that was stated.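

Among these compounds, compound 4 gives a number rather than a limit in this assay, and this yields the first step at this position between two measured numbers: a 1.3-fold lower number from compound 2 to compound 4 (0.10 log units; within the scatter). The other two steps give only floors, an at least 1.3-fold lower number from compound 3 to compound 4 (0.13 log units; that floor lies within the scatter) and an at least 1.6-fold lower number from compound 1 to compound 4 (0.21 log units; that floor lies within the scatter), so no readable step at this position has yet gone beyond the scatter, and their full sizes cannot be read. The entry for compound 3 is a limit: the limit of >= 260000 nM in this assay, at which 1 of the 4 values shown sits.

Still open, from the compounds shown here alone, is how far compound 1 lies from the other compounds, as its entry is also a limit: the limit of > 316000 nM in this assay, at which 1 of the 4 values shown sits. Also open is whether an aryl group carrying an amine or a carboxylic acid, or a longer chain on the carbon with a double bond to nitrogen, would move this assay beyond the scatter.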